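The compounds below may be only part of what the source reports. "The series", "measured", "known", "first", "only" and "open" are said of these compounds alone.

Measured compounds:
- compound 1 `O=C(Nc1ccccc1Cl)Nc1nn(-c2ccccc2)c(=O)c2ccccc12`: 0%
- compound 2 `O=C(Nc1ccc(Cl)cc1)Nc1nn(-c2ccccc2)c(=O)c2ccccc12`: 10%
- compound 3 `O=C(Nc1nn(-c2ccccc2)c(=O)c2ccccc12)c1ccco1`: 23%

All three were tested in an assay on CHO cells for displacement of a labelled ligand from adenosine receptor A1 (Homo sapiens), tested at 10 uM; a lower number here means less inhibition, a higher number more inhibition at the concentration tested (going by the name of the read-out). Compound 1 stands lowest of the three; compound 2 is its nearest neighbour, with a number 10 percentage points higher from compound 1 to compound 2 (within the scatter), and compound 3 is furthest, with a number 23 percentage points higher from compound 1 to compound 3 (beyond the scatter). Among the measured compounds shown here, the step of a number 13 percentage points higher from compound 2 to compound 3 (beyond the scatter) is also modest, so the whole series so far spans only a narrow band of inhibition.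

The unmeasured compound 4 `COc1ccccc1CNC(=O)Nc1nn(-c2ccccc2)c(=O)c2ccccc12` differs from compound 1 by 2-methoxybenzyl in place of 2-chlorophenyl on an amide-type nitrogen. For the measured compounds named here, the only measured step at the same amide-type nitrogen is the one from compound 1 to compound 2, exchanging one chlorophenyl for another, and it stayed within the scatter. The steps to compound 3 alter the carbonyl side instead and do not bear directly on a change at the nitrogen. Going by the values given here, no measured step shows the effect of a benzyl group or a methoxy group here, so the expectation rests on the small range of the series. A step of a number 10 percentage points higher from compound 1 to compound 4 (within the scatter) is expected, within or at the edge of the scatter. Compound 4 is therefore estimated at 10%, with a range from 0% to 30%.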

Compound 4, a percentage reported as inhibition, at one concentration (the size of the read-out at that concentration, not a potency): 28%
For compound 4 the middle estimate is 18 percentage points below the measured one, within the range that was stated.
By their numbers in this assay, from the lowest: compounds 1 and 2 (each within the scatter of the next); then compounds 3 and 4 (each within the scatter of the next).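

Among the compounds shown here, at the amide-type nitrogen, 2-methoxybenzyl gives the first change at this position that lies beyond the scatter in this assay, with a number 28 percentage points higher from compound 1 to compound 4 (beyond the scatter) and a number 18 percentage points higher from compound 2 to compound 4 (beyond the scatter), where the exchange of one chlorophenyl for the other did not. A substituent on this nitrogen can therefore bring the series level with the furan-2-yl compound on the carbonyl carbon, as a number 5 percentage points higher from compound 3 to compound 4 (within the scatter) leaves (2-methoxybenzyl)amino and furan-2-yl not told apart. Nothing measured on these compounds accounts for the shift.

Open, going by these compounds, is whether the shift follows the methoxy group, the added carbon of the benzyl link or both, which plain benzyl, 2-chlorobenzyl or a 2-phenylethyl chain on this nitrogen would separate. On these data alone, with a read-out at one concentration only, potency at the receptor also remains open.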